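From sec-butyl to cyclohexyl at the assay limit

The source may hold more compounds than are shown below. What is called first, only, known or untested is meant among the compounds shown, and "the series" means these compounds.

In an ADME assay on Caco-2 cells (Homo sapiens) for inhibition, read by MTT assay, with a stated time of 72 h (on this read-out lower numbers stand for stronger inhibition and higher numbers for weaker inhibition), compound 1 (`CCC(C)NC(=C\C(=O)/C=C/c1ccc(O)c(OC)c1)/C=C/c1ccc(O)c(OC)c1`) gives > 25000 nM as a limit of the assay and not as a number. Compound 2 (`COc1cc(/C=C/C(=O)/C=C(/C=C/c2ccc(OC(C)=O)c(OC)c2)NCC(C)C)ccc1OC(C)=O`) gives > 25000 nM as a limit too. The measured data therefore consist only of the limit of > 25000 nM in this assay, at which 2 of the 2 values shown sit, and hold no exact potency for either compound.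

Compound 3 (`COc1cc(/C=C/C(=O)/C=C(/C=C/c2ccc(O)c(OC)c2)NC2CCCCC2)ccc1O`) keeps the core of compound 1 and puts cyclohexyl in place of sec-butyl on an amine nitrogen. The counted difference reads cyclohexyl in place of sec-butyl on an amine nitrogen and adds a six-membered non-aromatic ring of carbon only. Within the data shown here, no two measured compounds differ in one place, so no measured step shows what such a swap does.

Among the measured compounds shown here, the only guide is that both measured compounds stand at the limit of > 25000 nM in this assay, at which 2 of the 2 values shown sit, and so a large gain in inhibition is not the expected outcome. The expected change is none beyond the usual scatter, and the estimated step is a step that the limit leaves unreadable from compound 1 to compound 3 in this assay with a limit again a likely report. The estimated value for compound 3 is 30000 nM with an expected range from 12000 nM to 75000 nM in repeated measurements.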

Compound 3, half-maximal inhibitory concentration: > 25000 nM
Compound 3: a limit, no number; the forecaster's own chance of this, stated with the estimate: 70%; the middle value lies beyond the limit too.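

In this assay compound 3 gives > 25000 nM, a limit of the assay and not a number. Compound 1 and compound 3 both carry only limits, so no step can be read between them. Still open is how strongly any of the compounds shown inhibits, and whether cyclohexyl in place of sec-butyl on the amine nitrogen changes that at all.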